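A few compounds are considered here, and "the series" means these few. Any claim that something is new, unique, unknown or untested is made for them only; others in the source may bear on it.

Series notes. Compound 1 `Cc1ccc2cnc(-c3cccc(Br)c3)nc2n1` gives 38 nM in a functional assay on CHO cells for antagonist activity at metabotropic glutamate receptor 5 (Rattus norvegicus), read by FLIPR and calcium flux; on this read-out higher numbers stand for weaker inhibition and lower numbers for stronger inhibition. Compound 2 `Cc1ccc2cnc(-c3cc(Cl)cc(Cl)c3)nc2n1` gives 0.72 nM in this assay, the lowest number among the three measured compounds, with both other values beyond the scatter from it. Compound 3 `Brc1cccc(-c2ncc3cccnc3n2)c1` gives 333 nM in this assay. The difference between the core of compound 1 and the core of compound 2 is not broken down here; the two values show a gap beyond the scatter. Compound 3 follows from compound 1 by one change, (hydrogen in place of methyl on an aromatic carbon), and the step is an 8.8-fold higher number from compound 1 to compound 3 (0.94 log units; beyond the scatter), a modest loss of inhibition.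

Compound 4 `Clc1cc(Cl)cc(-c2ncc3cccnc3n2)c1` is not yet measured in this assay. It follows from compound 2 by hydrogen in place of methyl on an aromatic carbon, the same change at the same place as that made from compound 1 to compound 3; among these compounds the change occurs twice in all. Among the compounds with values here, for compound 4 the expected step in this assay is an 8.3-fold higher number from compound 2 to compound 4 (0.92 log units; beyond the scatter), because the only measured instance of this change is an 8.8-fold higher number from compound 1 to compound 3 (0.94 log units; beyond the scatter). Starting from compound 2 at 0.72 nM, compound 4 is expected to give about 6 nM in this assay, between 1.5 nM and 25 nM.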

Compound 4, half-maximal inhibitory concentration: 228 nM
Estimate against measurement, compound 4: 38-fold (1.58 log units) below; the measured number lies above the stated range.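

Hydrogen in place of methyl on the aromatic carbon next to the ring nitrogen gives a 320-fold higher number from compound 2 to compound 4 (2.50 log units; beyond the scatter) in this assay, a large loss of inhibition. The direction of this change carries over from one core to the other, but its size does not: the same change on two cores in this assay, an 8.8-fold higher number (0.94 log units; beyond the scatter) from compound 1 to compound 3 and a 320-fold higher number (2.50 log units; beyond the scatter) from compound 2 to compound 4, 36-fold (1.56 log units) apart, beyond the scatter of two such steps
Within this series, the step measured on one core therefore cannot be used as a numerical estimate for the other, although two pairs establish no general rule for other cores and do not show what sets the size of the step.

Still open, going by these compounds, is whether the steep dependence on methyl in the compounds with two chlorines would persist with a longer chain such as ethyl, or with an amine, on that same carbon. Also open, on these data alone, is how the step behaves on a core carrying a nitrile in place of the bromine or the chlorines.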